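This account rests on a few compounds, and the source may have more. Where it says the series, first, only, none or still open, it means among the compounds named here.

Measured so far:
Compound 1, `COc1cc(/C=C/C(=O)c2cccc(N=[N+]=[N-])c2)ccc1O`, gives 7110 nM in a functional assay on RAW264.7 cells (Mus musculus) for inhibition, with a stated time of 4 days; on this read-out higher numbers stand for weaker inhibition and lower numbers for stronger inhibition.
Compound 2, `COc1cc(/C=C/C(=O)c2cccc(-n3cc(-c4ccccc4)nn3)c2)ccc1O`, gives 16800 nM in this assay.

Of these two numbers, compound 2 has the higher one, so on this read-out its inhibition is the weaker of the pair, and the gap to compound 1 lies beyond the usual scatter. Compound 3, `COc1ccc(-c2cn(-c3cccc(C(=O)/C=C/c4ccc(O)c(OC)c4)c3)nn2)cc1`, keeps everything in compound 2 except one change: methoxy in place of hydrogen on an aromatic carbon. Nothing measured here shows what that change does, so the expectation is a step of no more than the scatter, in either direction, with an estimated step of a 1.1-fold lower number from compound 2 to compound 3 (0.05 log units; within the scatter). Compound 3 is therefore expected to give about 15000 nM in this assay, most likely between 6000 nM and 40000 nM.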

Compound 3, half-maximal inhibitory concentration: 7900 nM
Estimate against measurement, compound 3: 1.9-fold (0.28 log units) above; low and high end bracket the measured number.
By their numbers in this assay, from the lowest: compounds 1 and 3 (each within the scatter of the next); then compound 2.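

Going from phenyl to 4-methoxyphenyl brings a 2.1-fold lower number from compound 2 to compound 3 (0.33 log units; beyond the scatter) in this assay. This shows that the aromatic carbon para to a large group is not indifferent to substitution, since methoxy there goes with stronger inhibition, though only by a modest step. No measurement available here explains why this step occurs. The compounds shown leave open whether another group at this place, such as hydroxy, an amine or a carboxylic acid, would move the number the same way. They also leave open whether methoxy would do so on another carbon of this ring.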